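Dichlorinated Pyridyl Ether Follows the Plain Pyridyl Ether

This account rests on a few compounds, and the source may have more. Where it says the series, first, only, none or still open, it means among the compounds named here.

Three compounds have been measured in an assay for inhibition of inositol hexakisphosphate kinase 2 (Homo sapiens), read by colorimetric assay, coupled enzyme assay and malachite green, with a stated time of 120 min, in the presence of a further agent that is not named here; on this read-out higher numbers stand for weaker inhibition and lower numbers for stronger inhibition:

Compound 1 `O=C(O)c1ccc2noc(-c3cccc(C(F)(F)F)c3)c2c1` gives 1460 nM.
Compound 2 `O=C(O)c1ccc2noc(-c3cccc(Oc4ccccc4)c3)c2c1` gives 130 nM.
Compound 3 `O=C(O)c1ccc2noc(-c3cccc(Oc4ccccn4)c3)c2c1` gives 690 nM.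

Among these three numbers compound 3 stands second highest: a 2.1-fold lower number from compound 1 to compound 3 (0.33 log units; beyond the scatter), while a 5.3-fold higher number from compound 2 to compound 3 (0.72 log units; beyond the scatter). Compound 4 `O=C(O)c1ccc2noc(-c3cccc(Oc4ncc(Cl)cc4Cl)c3)c2c1` differs from compound 3 by 3,5-dichloropyridin-2-yl in place of pyridin-2-yl on an oxygen on an aromatic ring. For the measured compounds named here, no measured step alters the substituents on the pyridyl ring itself; the only comparison at that end of the molecule is the aryl swap a 5.3-fold higher number from compound 2 to compound 3 (0.72 log units; beyond the scatter), which shows the ether terminus matters by a modest amount. The new step is therefore judged loosely, and compound 4 is expected to give 350 nM, within 100 nM to 1200 nM, an expected 2.0-fold lower number from compound 3 to compound 4 (0.29 log units; within the scatter).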

Compound 4, half-maximal inhibitory concentration: 71 nM
Beside the measured number, compound 4's estimate is 4.9-fold (0.69 log units) above it; the whole stated range lies above it.
By their numbers in this assay, from the lowest: compounds 4 and 2 (each within the scatter of the next); then compound 3; then compound 1.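

For the compounds shown here, putting 3,5-dichloropyridin-2-yl on the oxygen in place of pyridin-2-yl gives a 9.7-fold lower number from compound 3 to compound 4 (0.99 log units; beyond the scatter), so substituents on the pyridyl ring itself, which no earlier step touched, clearly move this number. With a 1.8-fold lower number from compound 2 to compound 4 (0.26 log units; within the scatter), the dichlorinated pyridyl ether and the phenyl ether cannot be told apart, while a 21-fold lower number from compound 1 to compound 4 (1.31 log units; beyond the scatter) is the widest step yet from the trifluoromethyl compound. Nothing on hand says why the two chlorines have this effect.

As far as these compounds go, whether one chlorine alone, as in 5-chloropyridin-2-yl, would have the same effect stays open. So does the outcome with methyl or methoxy in place of chlorine on that ring.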